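Nitro to methoxy swap, cytotoxicity expectation

This account rests on a few compounds, and the source may have more. Where it says the series, first, only, none or still open, it means among the compounds named here.

Compound 1 `CC(=O)N1N=C(c2cc3ccccc3nc2C)CC1c1ccc([N+](=O)[O-])cc1`: in an ADME assay on A549 cells (Homo sapiens) for cytotoxicity, read by MTT assay, with a stated time of 48 h (a lower number here means a stronger inhibitor, a higher number a weaker inhibitor), the value for compound 1 is > 200 ug/mL, a limit of the assay.
Compound 2 `CC(=O)N1N=C(c2cc3c(Cl)cccc3nc2C)CC1c1ccc(C)cc1`: in this assay compound 2 gives 166 ug/mL.

Going by the values given here, compound 1 stands only at a limit; no number is in hand for it, only that its value lies beyond the range the assay reports. Among the compounds with values here, compound 2 differs from compound 1 in more than one place, so no single step between the two is drawn; both sit at the weak end of what this assay covers (the limit of > 200 ug/mL in this assay, at which 1 of the 2 values shown sits). Compound 3 `COc1ccc(C2CC(c3cc4ccccc4nc3C)=NN2C(C)=O)cc1` is not yet measured in this assay. It differs from compound 1 by methoxy in place of nitro on an aromatic carbon. Within the data shown here, with compound 1 known only as a limit, no measured pair gives a step size for this change; the step expected from compound 1 to compound 3 is an at least 1.0-fold lower number from compound 1 to compound 3 (0.02 log units; that floor lies within the scatter), nothing beyond the scatter. For compound 3 the expected value in this assay is 190 ug/mL, with a range from 110 ug/mL to 330 ug/mL, and a fair chance that only a limit is reported again.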

Compound 3, half-maximal inhibitory concentration: 116 ug/mL
The estimate for compound 3 lay 1.6-fold (0.21 log units) above the measured number; the measured number falls inside the stated range.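

Changing 4-nitrophenyl to 4-methoxyphenyl on an otherwise unchanged core takes the series from a limit to a number in this assay: the limit of > 200 ug/mL in this assay, at which 1 of the 3 values shown sits. The change reads as an at least 1.7-fold lower number from compound 1 to compound 3 (0.23 log units; that floor lies within the scatter), so the data give a floor only and do not establish a real difference beyond the scatter. Compound 1 stands at > 200 ug/mL, a limit of the assay and not a number, so the full size of the change cannot be read.

Still open, on these data alone, is how the read-out responds to other groups at this aromatic carbon, such as an amine, a carboxylic acid or a longer chain like butoxy in place of methoxy. Compound 2 differs from compound 1 and compound 3 in more than one place, so it cannot settle this.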